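The source may report more compounds than this note shows. Statements on the series, on what has been measured and on what is new or still open speak of the compounds shown alone.

Within the data shown here, compound 2, `O=C1NC(=O)/C(=C/c2ccc(OCCSc3nnc(-c4ccc(Cl)cc4)[nH]3)cc2)S1`, is one of two compounds measured in a functional assay on the whole organism (plasma, strain Wistar) with Rattus norvegicus as the target, with a stated time of 15 days, at a dose of 3 mg/kg by the oral route; on this read-out higher numbers stand for a stronger effect at the one dose given and lower numbers for a weaker effect. Compound 2 gives 16% in this assay, while compound 1, `O=C1NC(=O)/C(=C/c2ccc(OCCSc3nnc(-c4ccc([N+](=O)[O-])cc4)[nH]3)cc2)S1`, gives 11.9%. The single step connecting the two, a number 4.1 percentage points higher from compound 1 to compound 2 (within the scatter), is within the scatter, so compound 2 and compound 1 stand together on the numbers shown, with neither set apart from the other.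

Compound 3, `COc1ccc(-c2nnc(SCCOc3ccc(/C=C4\SC(=O)NC4=O)cc3)[nH]2)cc1`, is not yet measured. It differs from compound 2 in one place: methoxy in place of chloro on an aromatic carbon. Among the measured compounds shown here, the only measured step that bears on this position is the one from compound 1 to compound 2, which exchanged one group for another at the same aromatic carbon and stayed within the scatter. For the measured compounds named here, no measured compound carries a methoxy, so nothing shows how this new group behaves in this assay. The step from compound 2 to compound 3 is therefore expected to be a number 1 percentage points lower from compound 2 to compound 3 (within the scatter), not beyond the scatter in either direction. For compound 3 the estimated value in this assay is 15%, expected to fall between 5% and 28%.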

Compound 3, a percentage reported as activity, at one dose (the size of the read-out at that dose, not a potency): 41.3%
Compound 3: middle estimate off by 26.3 percentage points, on the low side; measured number above the stated range.
By their numbers in this assay, from the lowest: compounds 1 and 2 (each within the scatter of the next); then compound 3.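

The new result shows that the group on this aromatic carbon can matter in this assay, which the earlier exchange of nitro for chloro, a number 4.1 percentage points higher from compound 1 to compound 2 (within the scatter), gave no sign of. Methoxy separates itself from both earlier groups, with a number 25.3 percentage points higher from compound 2 to compound 3 (beyond the scatter) and a number 29.4 percentage points higher from compound 1 to compound 3 (beyond the scatter), so compound 3 stands apart while compound 1 and compound 2 stay together. The computed difference between compound 2 and compound 3 is small, one extra heavy atom and one hydrogen-bond acceptor where chloro has none, but these counts are only a description, and nothing available explains why methoxy behaves differently here.

The compounds shown leave open whether the higher number depends on the oxygen, the added carbon or the whole methoxy group, a question that a hydroxyl group, an ethoxy group or a dimethylamino group on the same carbon could help to settle. With each compound read at a single dose, they also leave open how far this step reflects a change in potency rather than only the size of the effect at that dose.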